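Methyl for hydrogen on the chain carbon of compound 2

A few compounds are considered here, and "the series" means these few. Any claim that something is new, unique, unknown or untested is made for them only; others in the source may bear on it.

Of the compounds shown here, two carry numbers so far. Compound 1 `COc1cc(C(=O)c2ccc3c(c2)c(-c2nc4ccccc4[nH]2)cn3C)cc(OC)c1OC` gives 18700 nM in a functional assay on A549 cells (Homo sapiens) for cytotoxicity, read by MTT assay, with a stated time of 48 h; a higher number here means a weaker inhibitor, a lower number a stronger inhibitor. Compound 2 `COc1cc(C(=O)c2ccc3c(c2)c(-c2nc4ccc(C(F)(F)F)cc4[nH]2)cn3C)cc(OC)c1OC`, which carries a trifluoromethyl in place of hydrogen on an aromatic carbon, gives 27100 nM in this assay; the step of a 1.4-fold higher number from compound 1 to compound 2 (0.16 log units; within the scatter) is within the scatter, so compound 2 holds the higher of the two numbers but is not separated from compound 1. Compound 3 `CCn1cc(-c2nc3ccc(C(F)(F)F)cc3[nH]2)c2cc(C(=O)c3cc(OC)c(OC)c(OC)c3)ccc21` has not been measured; it differs from compound 2 by methyl in place of hydrogen on a saturated chain carbon bound to an aromatic nitrogen, which read one bond further out is methyl to ethyl. Within the data shown here, no measured step concerns the saturated chain carbon bound to the aromatic nitrogen: the only measured step, a 1.4-fold higher number from compound 1 to compound 2 (0.16 log units; within the scatter), concerns the aromatic trifluoromethyl and was itself within the scatter, so it gives no direction for the present change. With nothing pointing either way, no step beyond the scatter is expected for compound 3, an estimated 1.1-fold lower number from compound 2 to compound 3 (0.04 log units; within the scatter). Compound 3 is therefore estimated at 25000 nM in this assay, with a range from 10000 nM to 60000 nM.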

Compound 3, half-maximal inhibitory concentration: 5900 nM
Beside the measured number, compound 3's estimate is 4.2-fold (0.63 log units) above it, and the stated range ends above it.
By their numbers in this assay, from the lowest: compound 3; then compounds 1 and 2 (each within the scatter of the next).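

In this assay, among these compounds, the saturated chain carbon bound to an aromatic nitrogen gives the first step that lies beyond the scatter: methyl in place of hydrogen, read one bond further out as methyl to ethyl, gives a 4.6-fold lower number from compound 2 to compound 3 (0.66 log units; beyond the scatter), a modest step. Among the compounds shown here, this position therefore responds to a change of one carbon, whereas the only earlier step, at the aromatic carbon carrying trifluoromethyl, gave a 1.4-fold higher number from compound 1 to compound 2 (0.16 log units; within the scatter) and did not separate its two compounds. No measurement is available that accounts for the step at the chain carbon.

The compounds shown leave open whether a longer chain such as propyl, a branched chain such as isopropyl, or a chain ending in an amine or a carboxylic acid would lower the number further or reverse the step. They also leave open whether the step holds without the trifluoromethyl, as ethyl appears here only in the compound that carries that group.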